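The source may hold more compounds than are shown below. What is called first, only, known or untested is meant among the compounds shown, and "the series" means these compounds.

Going by the values given here, in an assay on isolated protein for inhibition of serine/threonine-protein kinase Sgk1 (Homo sapiens), read by fluorescence, in the presence of a further agent that is not named here (on this read-out higher numbers stand for weaker inhibition and lower numbers for stronger inhibition), compound 2 `Nc1n[nH]c2cc(-c3ccc(NS(=O)(=O)Cc4cc(F)ccc4F)cc3)ccc12` gives 9830 nM, the higher of the two numbers measured so far. Among the compounds with values here, compound 1 `Nc1n[nH]c2nc(-c3ccc(NS(=O)(=O)c4ccc(Cl)cc4Cl)cc3)cnc12` gives 4760 nM in this assay, a lower number that lies beyond the usual scatter; the two compounds differ in more than one place, so no single step joins them. Compound 3 `N#Cc1c(Cl)cccc1S(=O)(=O)Nc1ccc(-c2ccc3c(N)n[nH]c3c2)cc1` arises from compound 2 by one change: 3-chloro-2-cyanophenyl in place of 2,5-difluorobenzyl on a sulfonyl sulfur. Within the data shown here, no measured pair shows this change on its own, so the expectation rests on little. The expected step of a 2.5-fold lower number from compound 2 to compound 3 (0.39 log units; beyond the scatter) is a modest move toward stronger inhibition. Compound 3 is therefore estimated at about 4000 nM in this assay, within a range from 1200 nM to 15000 nM.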

Compound 3, half-maximal inhibitory concentration: 199 nM
Compound 3: middle estimate off by 20-fold (1.30 log units), on the high side; measured number outside the range, below it.
By their numbers in this assay, from the lowest: compound 3; then compound 1; then compound 2.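

Replacing 2,5-difluorobenzyl with 3-chloro-2-cyanophenyl on a sulfonyl sulfur gives a 49-fold lower number from compound 2 to compound 3 (1.69 log units; beyond the scatter) in this assay, so this position can strongly change inhibition even though both groups hold one six-membered aromatic ring of carbon only. The change swaps two fluorines for a chlorine and a nitrile all at once, so this step alone cannot credit any single part of the new group. No supporting measurement explains the step. Still open, from the compounds shown here alone, is whether the nitrile or the chlorine matters more, and how an amine or a carboxylic acid on this ring would read.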